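The compounds below may be only part of what the source reports. "The series", "measured", "known", "first", "only" and "open" are said of these compounds alone.

Measured compounds:
compound 1 `CC(C)N1CCN(Cc2csc(N)c2C(=O)c2ccc(Cl)cc2)CC1`: 0%
compound 2 `Nc1scc(CN2CCN(c3ccc(Cl)cc3Cl)CC2)c1C(=O)c1ccc(Cl)cc1`: 0%
compound 3 `Nc1scc(CN2CCN(c3ccc(OC(F)(F)F)cc3)CC2)c1C(=O)c1ccc(Cl)cc1`: 1%

In an assay on CHO cells for displacement of a labelled ligand from adenosine receptor A3 (Homo sapiens), read by scintillation counting, with a stated time of 120 min, tested at 10 uM (a higher number here means more inhibition at the concentration tested (going by the name of the read-out), a lower number less inhibition), compound 2 gives 0%, level with compound 1 and together the lowest of the three numbers; the step of a number 1 percentage points higher from compound 2 to compound 3 (within the scatter) lies within the scatter, as does no change at the digits printed from compound 1 to compound 2 (within the scatter). All three compounds share the core of compound 1 and differ only in the group on the amine nitrogen in the ring, and none shows inhibition beyond the scatter.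

Compound 4 `Nc1scc(CN2CCN(c3ccc(F)c(F)c3)CC2)c1C(=O)c1ccc(Cl)cc1` is not yet measured. Its change from compound 2: 3,4-difluorophenyl in place of 2,4-dichlorophenyl on an amine nitrogen in a ring. The two measured steps at this position, no change at the digits printed from compound 1 to compound 2 (within the scatter) and a number 1 percentage points higher from compound 2 to compound 3 (within the scatter), were both within the scatter, so no step beyond the scatter is expected, a number 1 percentage points higher from compound 2 to compound 4 (within the scatter). For compound 4 the estimate in this assay is 1%, range -8% to 10%.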

Compound 4, a percentage reported as inhibition, at one concentration (the size of the read-out at that concentration, not a potency): 1%
Estimate against measurement, compound 4: no gap at the digits printed, within the range that was stated.
By their numbers in this assay, from the lowest: compounds 1, 2, 3 and 4 (each within the scatter of the next).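

In this assay, the 3,4-difluorophenyl group extends this position to a fluorinated aryl group of the same heavy-atom count as 2,4-dichlorophenyl, and the step is a number 1 percentage points higher from compound 2 to compound 4 (within the scatter). The other two steps also show no separation, with no change at the digits printed from compound 3 to compound 4 (within the scatter) and a number 1 percentage points higher from compound 1 to compound 4 (within the scatter), so four different groups on this amine nitrogen in a ring give no step beyond the scatter. No evidence bearing on the reason for this result is available. From the compounds shown here alone, whether a carboxylic acid, an amide or a longer chain on this nitrogen would give a step beyond the scatter remains open. Also open, going by these compounds, is whether any group here can give measurable inhibition on the shared core.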